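Moving the Pyridine Nitrogen in an Ester Side Chain

The source may hold more compounds than are shown below. What is called first, only, known or untested is meant among the compounds shown, and "the series" means these compounds.

For the measured compounds named here, compound 2 `COc1nc(C)c(Nc2nc(Cl)cn([C@H](COC(=O)c3ccccn3)C3CC3)c2=O)cc1C` gives 67 nM in an assay on frontal cortex for displacement of a labelled ligand from corticotropin-releasing factor receptor 1 (Rattus norvegicus), with a stated time of 2 h (on this read-out higher numbers stand for weaker inhibition and lower numbers for stronger inhibition), the higher of the two numbers measured so far, while compound 1 `COc1nc(C)c(Nc2nc(Cl)cn([C@H](COC(C)=O)C3CC3)c2=O)cc1C` gives 5.3 nM. Going by the values given here, the single recorded step, a 13-fold higher number from compound 1 to compound 2 (1.10 log units; beyond the scatter), shows that the group on the carbonyl carbon matters. Compound 3 `COc1nc(C)c(Nc2nc(Cl)cn([C@H](COC(=O)c3cccnc3)C3CC3)c2=O)cc1C` differs from compound 2 by pyridin-3-yl in place of pyridin-2-yl on a carbonyl carbon. Among the compounds with values here, no measured step covers a change of this kind. A modest shift in either direction is therefore expected: a 1.3-fold lower number from compound 2 to compound 3 (0.13 log units; within the scatter). Compound 3 is estimated at 50 nM, with a range from 15 nM to 200 nM.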

Compound 3, half-maximal inhibitory concentration: 5.2 nM
Beside the measured number, compound 3's estimate is 9.6-fold (0.98 log units) above it, and the stated range ends above it.
By their numbers in this assay, from the lowest: compounds 3 and 1 (each within the scatter of the next); then compound 2.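

Moving the ring nitrogen alone, with the same atoms in the side chain, gives a 13-fold lower number from compound 2 to compound 3 (1.11 log units; beyond the scatter). Compound 2 and compound 3 both carry a pyridine ring on this carbonyl carbon, so the presence of such a ring does not always go with the weaker inhibition seen for compound 2. Pyridin-3-yl in place of methyl gives a 1.0-fold lower number from compound 1 to compound 3 (0.01 log units; within the scatter), so a ring at this place can match the small acetyl ester. Nothing measured here explains the gap between the two pyridine isomers. The compounds shown leave open how pyridin-4-yl, phenyl or a longer alkyl chain on the carbonyl carbon would compare, and what an amide in place of the ester would do.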